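Moving the trifluoromethyl around the benzyl ether

A few compounds are considered here, and "the series" means these few. Any claim that something is new, unique, unknown or untested is made for them only; others in the source may bear on it.

Measured so far in a functional assay on U-251 cells (Homo sapiens) for antiproliferative activity, read by MTT assay, with a stated time of 24 h; a higher number here means a weaker inhibitor, a lower number a stronger inhibitor:
- compound 1 `COc1cccc(C(=O)Oc2ccc3c(=O)c(-c4cc(OC)c(OC)cc4OC)coc3c2)c1`: > 10000 nM, a limit of the assay, not a number
- compound 2 `COc1cc(OC)c(-c2coc3cc(OCc4ccccc4C(F)(F)F)ccc3c2=O)cc1OC`: > 10000 nM, again only a limit

Compound 2 therefore stands at the limit, not at a measured number, as does compound 1 (the limit of > 10000 nM in this assay, at which 2 of the 2 values shown sit). Among the measured compounds shown here, the only computed step, a step that the two limits leave unreadable from compound 1 to compound 2, is unreadable because both ends are limits (the limit of > 10000 nM in this assay, at which 2 of the 2 values shown sit), so no measured step shows how the benzyl ether tolerates change.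

Compound 3 `COc1cc(OC)c(-c2coc3cc(OCc4cccc(C(F)(F)F)c4)ccc3c2=O)cc1OC` differs from compound 2 only in the position of the trifluoromethyl: 3-(trifluoromethyl)phenyl in place of 2-(trifluoromethyl)phenyl on a saturated chain carbon bound to an oxygen on an aromatic ring. With no readable step to lean on, the expectation rests on compound 2 sitting at the limit > 10000 nM; the same outcome is expected for compound 3, so the expected step that the limit leaves unreadable from compound 2 to compound 3 is none beyond the scatter. Compound 3 is estimated at 15000 nM, within 5000 nM to 50000 nM, most likely reported as a limit again.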

Compound 3, half-maximal inhibitory concentration: > 10000 nM
Compound 3: only a limit was reported; the forecaster's own chance of this, stated with the estimate: 75%; the middle value does not contradict the limit.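

In this assay compound 3 gives > 10000 nM, a limit and not a number, so no step among compound 1, compound 2 and compound 3 can be read: the limit of > 10000 nM in this assay, at which 3 of the 3 values shown sit.

The compounds shown leave open whether the change from 2-(trifluoromethyl)benzyl to 3-(trifluoromethyl)benzyl alters antiproliferative activity at all.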